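Dichlorophenyl isomers on the oxygen-linked chain: working notes

The source may hold more compounds than are shown below. What is called first, only, known or untested is meant among the compounds shown, and "the series" means these compounds.

- Compound 1 `CC(C)(C)c1ccc(OCCCON2C(N)=NC(N)=NC23CCSCC3)cc1` gives 280 nM
- Compound 2 `COc1ccc(OCCCON2C(N)=NC(N)=NC23CCOCC3)cc1` gives 1670 nM
- Compound 3 `NC1=NC2(CCOCC2)N(OCCCOc2cccc(Cl)c2Cl)C(N)=N1` gives 440 nM

In a functional assay on HL-60 cells (Homo sapiens) for antiproliferative activity, read by MTT assay, with a stated time of 72 h (a higher number here means a weaker inhibitor, a lower number a stronger inhibitor), compound 3 gives 440 nM and stands within the scatter of compound 1, with the number for compound 2 clearly higher. Compound 4 `NC1=NC2(CCOCC2)N(OCCCOc2ccc(Cl)cc2Cl)C(N)=N1` differs from compound 3 as follows: 2,4-dichlorophenyl in place of 2,3-dichlorophenyl on an oxygen on a saturated carbon with 2,4-dichlorophenyl in place of 2,3-dichlorophenyl on an oxygen on a saturated carbon. Among the compounds with values here, the one measured step at this place is a 3.8-fold lower number from compound 2 to compound 3 (0.58 log units; beyond the scatter) and it exchanged 4-methoxyphenyl for 2,3-dichlorophenyl. Within the data shown here, no measured step compares two dichlorophenyl groups, so no step beyond the scatter is expected in this assay here. The estimated step is a 1.1-fold lower number from compound 3 to compound 4 (0.04 log units; within the scatter) and it carries no firm direction. Compound 4 is expected at 400 nM with an estimated range from 170 nM to 950 nM in this series.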

Compound 4, half-maximal inhibitory concentration: 330 nM
Beside the measured number, compound 4's estimate is 1.2-fold (0.08 log units) above it, within the range that was stated.
By their numbers in this assay, from the lowest: compounds 1, 4 and 3 (each within the scatter of the next); then compound 2.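

In this assay, the exchange of dichlorophenyl isomers at this place gives a 1.3-fold lower number from compound 3 to compound 4 (0.12 log units; within the scatter), so the two chlorine patterns cannot be told apart here. The advantage over 4-methoxyphenyl is not confined to 2,3-dichlorophenyl, since the second isomer gives a 5.1-fold lower number from compound 2 to compound 4 (0.70 log units; beyond the scatter). Nothing available accounts for either step.

Going by these compounds, whether an unsubstituted phenyl or a pyridyl group would read the same at this place stays open. On these data alone, the effect of a longer chain carrying these dichlorophenyl groups also stays open.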